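Shortening the propyl chain on compound 2

The compounds below may be only part of what the source reports. "The series", "measured", "known", "first", "only" and "open" are said of these compounds alone.

Within the data shown here, compound 2 `CCCc1ccc(N2C(=O)NC3(CSC4=C3C(=O)c3ncccc3C4=O)C2=O)cc1` gives 2 nM in a functional assay on MCF7 cells (Homo sapiens) for antiproliferative activity, read by MTT assay, with a stated time of 96 h (on this read-out lower numbers stand for stronger inhibition and higher numbers for weaker inhibition), the lowest of the three numbers measured so far. Compound 1 `CN(C)c1ccc(N2C(=O)NC3(CSC4=C3C(=O)c3ncccc3C4=O)C2=O)cc1` gives 10 nM in this assay, and compound 3 `O=C1NC(=O)C2(CSC3=C2C(=O)c2ncccc2C3=O)N1`, which carries a hydrogen on the ring nitrogen, gives 120 nM. The steps between them are a 5.0-fold lower number from compound 1 to compound 2 (0.70 log units; beyond the scatter) and a 60-fold higher number from compound 2 to compound 3 (1.78 log units; beyond the scatter); the step of a 12-fold higher number from compound 1 to compound 3 (1.08 log units; beyond the scatter) closes the triangle.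

Compound 4 `Cc1ccc(N2C(=O)NC3(CSC4=C3C(=O)c3ncccc3C4=O)C2=O)cc1` differs from compound 2 by hydrogen in place of ethyl on a saturated chain carbon bound to an aromatic carbon. Among the measured compounds shown here, no measured step shortens this chain directly. The step of a 60-fold higher number from compound 2 to compound 3 (1.78 log units; beyond the scatter) removes the whole 4-propylphenyl group and is large, while a 5.0-fold lower number from compound 1 to compound 2 (0.70 log units; beyond the scatter) exchanges dimethylamino for propyl and is modest. Compound 4 keeps the aryl group and only trims its chain, so most of what compound 3 lost should be retained, and a small to modest upward step in this assay is expected, well short of the loss seen in compound 3. Compound 4 is therefore expected to give 4 nM in this assay, within 1.5 nM to 12 nM. The expected step is a 2.0-fold higher number from compound 2 to compound 4 (0.30 log units; within the scatter).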

Compound 4, half-maximal inhibitory concentration: 2 nM
Compound 4: middle estimate off by 2.0-fold (0.30 log units), on the high side, within the range that was stated.
By their numbers in this assay, from the lowest: compounds 2 and 4 (each within the scatter of the next); then compound 1; then compound 3.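

In this assay, the ethyl portion of the propyl chain can go with no change at the digits printed from compound 2 to compound 4 (within the scatter), so on this saturated chain carbon bound to an aromatic carbon, the full propyl length is not required to keep the number low. Methyl alone on the aryl group keeps the whole gain over the unsubstituted ring nitrogen, with a 60-fold lower number from compound 3 to compound 4 (1.78 log units; beyond the scatter), and the contrast with dimethylamino remains, with a 5.0-fold lower number from compound 1 to compound 4 (0.70 log units; beyond the scatter) as the step. No measurement on these compounds accounts for any of these steps.

Still open, going by these compounds, is whether a plain phenyl group, with hydrogen in place of methyl, would hold this level. Equally open, on these data alone, is how a longer chain such as hexyl, or a carboxylic acid or primary amine on the same aromatic carbon, would read here.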